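A few compounds are considered here, and "the series" means these few. Any claim that something is new, unique, unknown or untested is made for them only; others in the source may bear on it.

Compound 1 `COc1cc(C(=O)Nc2nn[nH]n2)nc(-c2ccccc2)c1` is the stronger of the two compounds measured in a functional assay on the whole organism with Rattus norvegicus as the target, at a dose of 3 mg/kg by the oral route (a lower number here means a weaker effect, a higher number a stronger effect of the compound at the dose given), giving 97%. Within the data shown here, compound 2 `CNc1ccc(-c2cc(OC)cc(C(=O)Nc3nn[nH]n3)n2)cc1` gives 79% in this assay, and the one recorded step, a number 18 percentage points lower from compound 1 to compound 2 (beyond the scatter), is modest and beyond the scatter. Compound 3 `O=C(Nc1nn[nH]n1)c1cccc(-c2ccccc2)n1` has not yet been measured. It differs from compound 1 in a single place: hydrogen in place of methoxy on an aromatic carbon. Among the measured compounds shown here, no measured step matches this change: the only step known concerns methylamino in place of hydrogen at another aromatic carbon, so it gives no direct guidance on the loss of the methoxy. Because compound 1 already gives 97%, close to the top of the scale, an upward step is scarcely possible, and the removal of a group is more often met by a loss than a gain. Compound 3 is therefore estimated at 80%, within 45% to 98%. For the measured compounds named here, the expected step is a number 17 percentage points lower from compound 1 to compound 3 (beyond the scatter), a downward one, though its size is quite uncertain given that no comparable step exists among the measured compounds.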

Compound 3, a percentage reported as inhibition, in the whole organism at one dose (the size of the read-out at that dose, not a potency): 74%
Compound 3: the middle estimate sits 6 percentage points above what was measured; the range from low to high includes it.
By their numbers in this assay, from the lowest: compounds 3 and 2 (each within the scatter of the next); then compound 1.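

Among these compounds, replacing the methoxy opposite the ring nitrogen with hydrogen gives a number 23 percentage points lower from compound 1 to compound 3 (beyond the scatter) in this assay, the first reading of what this position contributes. The methoxy therefore goes with the higher number in this pair, yet it is not required for a clear effect: compound 3, without it, still gives 74% at the dose tested. No measured evidence available here bears on why the number falls with this change.

The compounds shown carry only methoxy or hydrogen at this position, so it remains open whether a hydroxyl, an ethoxy, an amine or a fluorine there would match the methoxy or fall closer to hydrogen. These are also readings at a single dose, so they leave open how the two compounds compare in potency.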